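Urea and thiourea analogs in a colon cancer cell assay

The source may hold more compounds than are shown below. What is called first, only, known or untested is meant among the compounds shown, and "the series" means these compounds.

Compounds measured so far:
Compound 1 `Cc1ccc(NC(=S)NC(=O)c2ccc(OCc3ccc(C(F)(F)F)cc3)cc2)cc1-c1nc2ccccc2[nH]1` — 72400 nM
Compound 2 `Cc1ccc(NC(=S)NC(=O)c2ccc(OCc3cccc(C(F)(F)F)c3)cc2)cc1-c1nc2ccccc2[nH]1` — 15400 nM
Compound 3 `Cc1ccc(NC(=O)NC(=O)c2ccc(OCc3cccc(C(F)(F)F)c3)cc2)cc1-c1nc2ccccc2[nH]1` — 9640 nM

All three were tested in a functional assay on SW-620 cells (Homo sapiens) for inhibition, read by MTT assay, with a stated time of 48 h; on this read-out lower numbers stand for stronger inhibition and higher numbers for weaker inhibition. Compound 3 gives the lowest number of the three. Its nearest neighbour is compound 2, whose number is higher only within the usual scatter, so the two cannot be told apart on these data. Compound 1 stands furthest away, with a number higher than compound 3 beyond the scatter.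

Compound 4 `Cc1ccc(NC(=O)NC(=O)c2ccc(OCc3ccc(Cl)cc3Cl)cc2)cc1-c1nc2ccccc2[nH]1` has not yet been measured. It differs from compound 3 in one place: 2,4-dichlorophenyl in place of 3-(trifluoromethyl)phenyl on a saturated chain carbon bound to an oxygen on an aromatic ring.

Going by the values given here, only one measured step touches the same part of the molecule. The step of a 4.7-fold lower number from compound 1 to compound 2 (0.67 log units; beyond the scatter) shows that changing the substitution on this ring, with everything else unchanged, produced a modest shift beyond the scatter. Among the compounds with values here, compound 4 changes the same ring again, but to a substitution that none of the measured compounds carries, so there is no direct precedent for its direction. Within the data shown here, because the one known change there was only modest in a 4.7-fold lower number from compound 1 to compound 2 (0.67 log units; beyond the scatter), the expected step of a 1.1-fold lower number from compound 3 to compound 4 (0.03 log units; within the scatter) is small, either way, with no strong reason for a shift beyond the scatter. Compound 4 is therefore estimated at 9000 nM in this assay, within a range from 3000 nM to 30000 nM.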

Compound 4, half-maximal inhibitory concentration: 12200 nM
Beside the measured number, compound 4's estimate is 1.4-fold (0.13 log units) below it; measured number inside the range.
By their numbers in this assay, from the lowest: compounds 3, 4 and 2 (each within the scatter of the next); then compound 1.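

In this assay, putting 2,4-dichlorophenyl in place of 3-(trifluoromethyl)phenyl on the saturated chain carbon gives a 1.3-fold higher number from compound 3 to compound 4 (0.10 log units; within the scatter), so compound 3 and compound 4 cannot be told apart on these data. The earlier step at this position, a 4.7-fold lower number from compound 1 to compound 2 (0.67 log units; beyond the scatter), concerned only where a trifluoromethyl group sat on the ring, and it showed that such a change can be read in this assay; the new step adds that a ring carrying two chlorine atoms and no trifluoromethyl group gives a number that cannot be separated from that of compound 3, so at this position a different substituent does not always bring a readable shift. Nothing available explains either the readable step or the unreadable one.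

What the compounds shown leave open is whether this position would respond to a group of a different kind on the ring, such as an amine or a carboxylic acid, or to a longer chain in place of the benzyl link. Going by these compounds alone, they also leave open whether 2,4-dichlorophenyl would behave the same way on the thiourea compounds, where the one readable step at this position was seen.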